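The source may hold more compounds than are shown below. What is called first, only, known or untested is meant among the compounds shown, and "the series" means these compounds.

Measured so far:
compound 1, `CN(C)CCCCOc1ccccc1/C=C/c1ccccc1Cl`: 14.3%
compound 2, `C(=C/c1ccccc1OCCCCN1CCCCC1)\c1ccccc1`: 42.9%
compound 3, `CN(C)CCCCOc1cccc(/C=C/c2ccccc2)c1`: 0%

All three were tested in a functional assay on the whole organism with Mus musculus as the target, in the maximal electroshock model, at a dose of 50 mg/kg by the oral route; on this read-out higher numbers stand for more inhibition at the one dose given (going by the name of the read-out) and lower numbers for less inhibition. Among these three numbers compound 2 stands highest: the nearest is compound 1, whose value lies lower by more than the usual scatter, and compound 3 sits furthest, also lower by more than the scatter. Compound 4, `CC(=O)N1CCN(CCCCOc2ccccc2/C=C/c2ccccc2)CC1`, has not yet been measured. It differs from compound 2 in one place: 4-acetylpiperazin-1-yl in place of piperidin-1-yl on a saturated chain carbon, four bonds along the chain from an oxygen on an aromatic ring. Going by the values given here, no pair of measured compounds shows a change of this kind, so its effect is unknown here. A moderate drop beyond the scatter is expected, a number 14.9 percentage points lower from compound 2 to compound 4 (beyond the scatter). Compound 4 is therefore expected to give about 28%, within a range from 0% to 57%.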

Compound 4, a percentage reported as inhibition, in the whole organism at one dose (the size of the read-out at that dose, not a potency): 0%
Beside the measured number, compound 4's estimate is 28 percentage points above it; the range from low to high includes it.
By their numbers in this assay, from the lowest: compounds 3 and 4 (each within the scatter of the next); then compound 1; then compound 2.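

In this assay, going by these compounds alone, the group at the end of the chain proves decisive: putting 4-acetylpiperazin-1-yl in place of piperidin-1-yl gives a number 42.9 percentage points lower from compound 2 to compound 4 (beyond the scatter), the first single-place change that can be read in this set. At this position, then, the response of compound 2 is not kept when this larger ring, with its second ring nitrogen and acetyl group, enters. No measurement at hand explains the loss. As far as these compounds go, it remains open whether the acetyl group or the second ring nitrogen matters more. Piperazin-1-yl without the acetyl group, or 4-methylpiperazin-1-yl, at the same place would help separate the two.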